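From Bromo to Ethyl: One Change on an Aromatic Ring

The compounds below may be only part of what the source reports. "The series", "measured", "known", "first", "only" and "open" are said of these compounds alone.

Compound 1 `Nc1ccccc1NC(=O)c1ccc(CSc2ccc(Br)cc2)cc1` gives the lower of two numbers in a functional assay on A-375 cells (Homo sapiens) for inhibition, read by CCK-8 assay, with a stated time of 72 h, tested at 2 uM (on this read-out lower numbers stand for less inhibition of growth and higher numbers for more inhibition of growth at the one concentration tested), at 4.35%. Compound 2 `CC(C)(C)c1ccc(SCc2ccc(/C=C/C(=O)Nc3ccccc3N)cc2)cc1` gives 38.4% in this assay, a gap beyond the usual scatter, but these two compounds differ in more than one place, so no single step can be read from them. Compound 3 `CCc1ccc(SCc2ccc(C(=O)Nc3ccccc3N)cc2)cc1` is compound 1 altered in one place: ethyl in place of bromo on an aromatic carbon. Within the data shown here, no measured pair shows this change alone; the expectation is a small rise in this assay, possibly no larger than the scatter, giving an expected step of a number 7.7 percentage points higher from compound 1 to compound 3 (within the scatter). Compound 3 is estimated at 12%, within 0% to 35%.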

Compound 3, percent growth inhibition at one concentration: 19.6%
Compound 3: middle estimate off by 7.6 percentage points, on the low side; the range from low to high includes it.
By their numbers in this assay, from the lowest: compound 1; then compound 3; then compound 2.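

In this assay, ethyl in place of bromo gives a number 15.3 percentage points higher from compound 1 to compound 3 (beyond the scatter) and so shows that this position, para to a large group, responds to a change of one group alone. The step is modest and is the only one at this position, so it gives a direction for this one change and not a trend. Nothing available explains the rise. On these data alone, how an amine, a carboxylic acid or a longer chain would behave in this place remains open. Also open, as far as these compounds go, is whether the rise belongs to ethyl or to the loss of bromo, which plain hydrogen here could help to separate.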